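Oxidising a thioether to a sulfone on a pyrimidine core

A few compounds are considered here, and "the series" means these few. Any claim that something is new, unique, unknown or untested is made for them only; others in the source may bear on it.

Of the compounds shown here, two sharing one core have been measured in a functional assay on Jurkat cells for inhibition of nuclear factor NF-kappa-B complex (Homo sapiens); a higher number here means a weaker inhibitor, a lower number a stronger inhibitor. Compound 1 `CCOC(=O)c1cnc(-c2ccc(F)cc2)nc1NN1C(=O)C=C(C)C1=O` gives 700 nM. Compound 2 `CCOC(=O)c1cnc(Sc2ccccc2)nc1NN1C(=O)C=C(C)C1=O` gives 1000 nM, which is the higher of the two numbers, yet the step of a 1.4-fold higher number from compound 1 to compound 2 (0.15 log units; within the scatter) is within the scatter, so the two compounds cannot be told apart on these data.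

Compound 3 `CCOC(=O)c1cnc(S(=O)(=O)c2ccccc2)nc1NN1C(=O)C=C(C)C1=O` is the next compound, not yet measured. It differs from compound 2 in one place: phenylsulfonyl in place of phenylsulfanyl on an aromatic carbon. The group sits on an aromatic carbon between two ring nitrogen atoms, para to the ethoxycarbonyl group.

Among the compounds with values here, only one measured step touches this position, the change from compound 1 to compound 2, and it stayed within the scatter. Within the data shown here, no measured pair shows a sulfanyl turned into a sulfonyl, so nothing here predicts a shift in either direction. The expected step from compound 2 onward is therefore a 1.2-fold higher number from compound 2 to compound 3 (0.08 log units; within the scatter), essentially none beyond the scatter, with a wide range to reflect the absence of direct evidence. In this assay compound 3 is estimated at 1200 nM, with a likely range from 400 nM to 4000 nM.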

Compound 3, half-maximal inhibitory concentration: 10000 nM
Beside the measured number, compound 3's estimate is 8.3-fold (0.92 log units) below it, outside the stated range (above it).
By their numbers in this assay, from the lowest: compounds 1 and 2 (each within the scatter of the next); then compound 3.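

This position is not indifferent to every change in this assay: compound 1 and compound 2 could not be told apart, but placing two oxygen atoms on the sulfur gives a 10-fold higher number from compound 2 to compound 3 (1.00 log units; beyond the scatter) and takes the number beyond the scatter. The phenyl ring stays in place across that step, so a change at the sulfur alone is enough to weaken inhibition, something the earlier pair could not show. Set against the 4-fluorophenyl group, the phenylsulfonyl group gives a 14-fold higher number from compound 1 to compound 3 (1.15 log units; beyond the scatter), which makes compound 3 the weakest inhibitor of the three, while the data shown offer no measured reason for the loss.

Still open, as far as these compounds go, is where a phenylsulfinyl group, with a single oxygen on the sulfur, would fall relative to compound 2 and compound 3. Also open, from the compounds shown here alone, is whether the loss belongs to the sulfonyl itself or to the sulfonyl together with its phenyl ring, which a methylsulfonyl group on the same aromatic carbon would help to separate, and whether an amine there would restore inhibition.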